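The compounds below may be only part of what the source reports. "The series", "measured", "known", "first", "only" and "open" are said of these compounds alone.

The three compounds whose numbers are in hand share a core and differ at two or three places around it. Compound 1 `COC(CCn1cnc2c(NCc3ccc(C(=O)Nc4ccccc4N)cc3)nc(Cl)nc21)OC` gives 43.7% in a functional assay on NCI-H460 cells (Homo sapiens) for antiproliferative activity, read by CCK-8 assay, with a stated time of 72 h, tested at 2 uM; on this read-out higher numbers stand for a stronger effect at the one concentration tested and lower numbers for a weaker effect. Compound 2 `Cc1ccc(Nc2nc(Cl)nc3c2ncn3Cc2ccc(/C=C/C(=O)Nc3ccccc3N)cc2)cc1` gives 31.3%, and compound 3 `Nc1ccccc1NC(=O)/C=C/c1ccc(Cn2cnc3c(Nc4cccc(Cl)c4)nc(Cl)nc32)cc1` gives 7.11%. On these numbers compound 1 stands highest of the three: compound 2 is nearest, with a number lower by an amount beyond the scatter, and compound 3 is furthest, with a number lower by an amount also beyond the scatter.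

Going by the values given here, only one pair of measured compounds differs in a single place, and that pair is compound 2 and compound 3: a number 24.2 percentage points lower from compound 2 to compound 3 (beyond the scatter). This step changes the aryl group on a nitrogen on an aromatic ring, a place that compound 4 does not touch.

Compound 4 `CC(C)n1cnc2c(NCc3ccc(C(=O)Nc4ccccc4N)cc3)nc(Cl)nc21` is compound 1 with one change: isopropyl in place of 3,3-dimethoxypropyl on an aromatic nitrogen. Among the compounds with values here, no measured pair changes the group on this aromatic nitrogen, so no step in hand bears on the change from compound 1 to compound 4, and the step from compound 2 to compound 3 speaks to a different place on the core. For this reason the expected step in this assay is none beyond the scatter, with the number for compound 4 expected to stay near that of compound 1, a number 4.7 percentage points lower from compound 1 to compound 4 (within the scatter). Compound 4 is therefore estimated to give 39% in this assay, with a range from 22% to 56%.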

Compound 4, a percentage reported as inhibition, at one concentration (the size of the read-out at that concentration, not a potency): 54.2%
Beside the measured number, compound 4's estimate is 15.2 percentage points below it; low and high end bracket the measured number.
By their numbers in this assay, from the lowest: compound 3; then compound 2; then compound 1; then compound 4.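

In this assay, going by these compounds alone, this is the first step read at the aromatic nitrogen of the five-membered ring: a number 10.5 percentage points higher from compound 1 to compound 4 (beyond the scatter). It shows that the group at this place can move the number beyond the scatter, and that the 3,3-dimethoxypropyl chain, with its 7 heavy atoms and 2 hydrogen-bond acceptors, is not needed for the effect at the one concentration tested, since isopropyl, with 3 heavy atoms and no acceptors, gives the higher number. The data offer no measurement that explains why the number rises with this change.

Since the change shortens the chain and removes both oxygens at once, this single step cannot separate the two, and a plain n-pentyl chain, a 3-methoxypropyl chain or a chain ending in an amine or a carboxylic acid on this nitrogen would be needed to tell them apart. Also open, on these data alone, is whether the same exchange would raise the number on compound 2 and compound 3, which differ from compound 1 elsewhere on the shared core.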